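The source may hold more compounds than are shown below. What is called first, only, known or untested is meant among the compounds shown, and "the series" means these compounds.

In an ADME assay on PBMC cells (Homo sapiens) for cytotoxicity, read by MTT assay, with a stated time of 72 h, in the absence of a further agent (a lower number here means a stronger inhibitor, a higher number a weaker inhibitor), compound 1 `COc1ccc(Nc2ccc3ccccc3n2)cc1` gives 91000 nM and compound 2 `Cc1ccc(-c2ccnc(Nc3ccc(F)cc3)c2)cc1` gives 127000 nM. These two numbers lie within the usual scatter of each other, so compound 2 stands level with compound 1.

Compound 3 `COc1ccc(Nc2cc(-c3ccc(C)cc3)ccn2)cc1` differs from compound 2 in one place: methoxy in place of fluoro on an aromatic carbon. Put simply, methoxy takes the place of fluoro on an aromatic carbon, para to a large group. Going by the values given here, no pair of measured compounds shows what this swap does, so the data offer no direct guide. Compound 1 also carries a methoxy group and gives 91000 nM, although the rest of its structure differs. A change no larger than the scatter is therefore expected, with neither direction favoured. The estimate amounts to an expected step of a 1.2-fold lower number from compound 2 to compound 3 (0.08 log units; within the scatter). For compound 3 the estimated value is 105000 nM, with an expected range of 50000 nM to 200000 nM.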

Compound 3, half-maximal inhibitory concentration: 52000 nM
Compound 3: the middle estimate sits 2.0-fold (0.31 log units) above what was measured; the range from low to high includes it.
By their numbers in this assay, from the lowest: compounds 3, 1 and 2 (each within the scatter of the next, the first and the last beyond it).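

In this assay, methoxy in place of fluoro on an aromatic carbon, para to a large group, gives a 2.4-fold lower number from compound 2 to compound 3 (0.39 log units; beyond the scatter). Going by these compounds alone, this is the first direct reading of this swap, and it shows that the group at this position can move the number by a modest step that lies beyond the scatter, with methoxy on the side of the stronger inhibitor. Nothing in the available data explains why the number moves in this direction.

On these data alone, it remains open whether an amine, a hydroxyl group or a longer chain such as ethoxy at the same place would lower the number further or raise it again. As far as these compounds go, it is also open whether the same swap would give a similar step on a different core.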